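A piperidine swap from compound 2 to compound 4

This account rests on a few compounds, and the source may have more. Where it says the series, first, only, none or still open, it means among the compounds named here.

In an ADME assay on microsomes from liver (Rattus norvegicus) for metabolic stability, read by LC-MS, using NADPH, at 37 degrees C (a lower number here means that the compound disappears faster, a higher number that the compound lasts longer), compound 2 (`Cc1ccccc1-c1nc(CN2CCC(C(=O)NCCCN3CCC(C)(C)CC3)CC2)c(C)o1`) gives only a limit and not a number, > 0.5 h as its half-life. Compound 2 therefore sits at the limit of > 0.5 h in this assay, at which 1 of the 3 values shown sits, and any step from it stays approximate.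

Compound 4 (`Cc1ccccc1-c1nc(CN2CCC(C(=O)NCCN3C[C@H](C)C[C@H](C)C3)CC2)c(C)o1`) differs from compound 2 in one place (3,5-dimethylpiperidin-1-yl in place of (4,4-dimethylpiperidin-1-yl)methyl on a saturated chain carbon, two bonds along the chain from an amide-type nitrogen): 3,5-dimethylpiperidin-1-yl stands in place of (4,4-dimethylpiperidin-1-yl)methyl on a saturated chain carbon, two bonds along the chain from an amide-type nitrogen.

Among the compounds with values here, no measured step shows this exact change. Compound 1 (`Cc1ccc(C)c(-c2nc(CN3CCC(C(=O)NCCCN4C[C@H](C)C[C@H](C)C4)CC3)c(C)o2)c1`) also carries 3,5-dimethylpiperidin-1-yl and gives 0.5 h as a measured number. Within the data shown here, compound 3 (`Cc1oc(-c2c(Cl)cccc2Br)nc1CN1CCC(C(=O)NCCCN2C[C@H](C)C[C@H](C)C2)CC1`) gives 0.0233 h in this assay and marks the one large step (a 21-fold lower number from compound 1 to compound 3 (1.33 log units; beyond the scatter)), with 2-bromo-6-chlorophenyl in place of 2,5-dimethylphenyl on an aromatic carbon. That step lies in a part that does not change between compound 2 and compound 4, so it sets no size here.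

With compound 1 at 0.5 h as the closest guide, no step beyond the scatter is expected in this assay and any shift should be towards a lower number. The estimated step is an at least 1.2-fold lower number from compound 2 to compound 4 (0.09 log units; that floor lies within the scatter) and it remains only an expectation. Compound 4 is expected to give 0.4 h with an estimated range from 0.15 h to 0.6 h in this measurement.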

Compound 4, half-life: > 0.5 h
Compound 4 ended at the assay's limit; the forecaster's own chance of this, stated with the estimate: 35%; middle value at least 1.2-fold (0.09 log units) from the limit.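

In this assay, compound 2 and compound 4 both give a limit and not a number, so no step between them can be read: the limit of > 0.5 h in this assay, at which 2 of the 4 values shown sit.

The compounds shown leave open how long either compound actually lasts, and so whether 3,5-dimethylpiperidin-1-yl in place of (4,4-dimethylpiperidin-1-yl)methyl changes the half-life at all.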